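Notes on amine variation in the shared core, compound 4 pending

A few compounds are considered here, and "the series" means these few. Any claim that something is new, unique, unknown or untested is made for them only; others in the source may bear on it.

Compound 1, `COCC(COC)Nc1nc(C)nc2c(-c3ccc(OC)cc3C)c(C)nn12`, gives 9.7 nM in an assay on cell membranes for displacement of a labelled ligand from corticotropin-releasing factor receptor 1 (Rattus norvegicus); a higher number here means a weaker inhibitor, a lower number a stronger inhibitor.
Compound 2, `COc1ccc(-c2c(C)nn3c(N4CCCC4)nc(C)nc23)c(C)c1`, gives 80.7 nM in this assay.
Compound 3, `CCN(CC)c1nc(C)nc2c(-c3c(C)cc(OC)cc3OC)c(C)nn12`, gives 1.2 nM in this assay.

Compound 2 stands highest of the three numbers in this assay; compound 1 is nearest and compound 3 furthest, both lower and both beyond the scatter. For the measured compounds named here, the one measured step that bears on the amine is an 8.3-fold higher number from compound 1 to compound 2 (0.92 log units; beyond the scatter): an open-chain amino group replaced by the ring amine, and the number rose. Compound 3 also carries an open-chain dialkylamino group, but its aryl ring differs from that of compound 2 as well, so those two values only show that compound 3 sits well below compound 2.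

Compound 4, `CCCN(CC1CC1)c1nc(C)nc2c(-c3ccc(OC)cc3C)c(C)nn12`, is not yet measured in this assay. It differs from compound 2 by (cyclopropylmethyl)(propyl)amino in place of pyrrolidin-1-yl on an aromatic carbon. Going by the values given here, this change runs opposite to the one whose step is an 8.3-fold higher number from compound 1 to compound 2 (0.92 log units; beyond the scatter), back from a ring amine to an open-chain dialkylamino group, so a lower number is expected, beyond the scatter, with an estimated step of a 13-fold lower number from compound 2 to compound 4 (1.13 log units; beyond the scatter). For compound 4 the estimate is 6 nM, expected to fall between 1.5 nM and 25 nM.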

Compound 4, half-maximal inhibitory concentration: 1.96 nM
The estimate for compound 4 lay 3.1-fold (0.49 log units) above the measured number; measured number inside the range.
By their numbers in this assay, from the lowest: compounds 3 and 4 (each within the scatter of the next); then compound 1; then compound 2.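

In this assay, the position between two ring nitrogen atoms now has a second open-chain group to set against pyrrolidin-1-yl: with the rest of the molecule unchanged, (cyclopropylmethyl)(propyl)amino gives a 41-fold lower number from compound 2 to compound 4 (1.61 log units; beyond the scatter) and so both open-chain groups shown sit below the ring amine. The open-chain groups are not interchangeable either, as (cyclopropylmethyl)(propyl)amino in place of (2-methoxy-1-(methoxymethyl)ethyl)amino gives a 4.9-fold lower number from compound 1 to compound 4 (0.69 log units; beyond the scatter) as a further, modest step. Nothing shown accounts for either step.

The compounds shown cannot separate the loss of the ring from the larger group, since the entering group has more heavy atoms than pyrrolidin-1-yl. From the compounds shown here alone, a larger ring amine such as piperidin-1-yl, or a dipropylamino group without the three-membered ring, remains open at this position.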